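The source may report more compounds than this note shows. Statements on the series, on what has been measured and on what is new or still open speak of the compounds shown alone.

Compound 2 `COc1nn(C)c2nc(C)nc(NS(=O)(=O)c3cccc(Cl)c3Cl)c12` stands at the higher end of the two numbers at hand. In a functional assay on cells for antagonist activity at C-C chemokine receptor type 4 (Homo sapiens), read by GTPgammaS binding (on this read-out higher numbers stand for weaker inhibition and lower numbers for stronger inhibition), compound 2 gives 631 nM, whereas compound 1 `COc1nn(C)c2ncnc(NS(=O)(=O)c3cccc(Cl)c3Cl)c12` gives 63.1 nM. Within the data shown here, the one measured step, a 10-fold higher number from compound 1 to compound 2 (1.00 log units; beyond the scatter), comes from putting a methyl in place of a hydrogen on an aromatic carbon of the shared core, and it lies beyond the usual scatter.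

Compound 3 `COc1nc(NS(=O)(=O)c2cccc(Cl)c2Cl)c2c(OC)nn(C)c2n1` has not been measured. It differs from compound 2 in one place: methoxy in place of methyl on an aromatic carbon. The change sits on the same aromatic carbon where the methyl of compound 2 already replaced the hydrogen of compound 1, between two ring nitrogen atoms. Among the measured compounds shown here, the only step that bears on it is a 10-fold higher number from compound 1 to compound 2 (1.00 log units; beyond the scatter), which shows that a group on this carbon weakened inhibition. Nothing measured here tells how methoxy behaves at that carbon, so the expectation is uncertain. A number near that of compound 2 is expected, with a step of a 1.6-fold higher number from compound 2 to compound 3 (0.20 log units; within the scatter) in this assay. For compound 3 the estimate in this assay is 1000 nM, within a range from 250 nM to 4000 nM.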

Compound 3, half-maximal inhibitory concentration: 794 nM
Beside the measured number, compound 3's estimate is 1.3-fold (0.10 log units) above it; the range from low to high includes it.
By their numbers in this assay, from the lowest: compound 1; then compounds 2 and 3 (each within the scatter of the next).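

In this assay, methoxy in place of methyl gives a 1.3-fold higher number from compound 2 to compound 3 (0.10 log units; within the scatter) and so cannot be told apart from methyl at this aromatic carbon between two ring nitrogen atoms, even though methoxy brings an oxygen that methyl lacks. Set against the hydrogen of compound 1, the same methoxy gives a 13-fold higher number from compound 1 to compound 3 (1.10 log units; beyond the scatter) and so confirms with a second group what methyl alone could only suggest: both groups tested at this carbon give weaker inhibition than hydrogen. Across these three compounds, the clear divide is therefore between hydrogen and a group at this carbon, while the choice between methyl and methoxy makes no measurable difference. Nothing shown here explains why either group weakens inhibition.

From the compounds shown here alone, it remains open whether every group at this carbon behaves this way, or whether a smaller atom such as fluorine, or an amine, would bring inhibition back toward that of compound 1. A longer chain such as ethoxy or propoxy is also untested among the compounds shown, so it is unknown whether inhibition would stay level with compound 3 or fall further.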